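Swapping the benzyl ether aryl group on a shared core

The source may hold more compounds than are shown below. What is called first, only, known or untested is meant among the compounds shown, and "the series" means these compounds.

Measured so far:
compound 1 `COc1cccc(OC)c1OCCNCCOc1ccccc1OCc1ccccc1Cl`: 17800 nM
compound 2 `COc1cccc(OC)c1OCCNCCOc1ccccc1OCc1cccc(C)c1`: 32300 nM

In a functional assay on PC-3 cells (Homo sapiens) for cytotoxicity, read by sulforhodamine B assay (on this read-out higher numbers stand for weaker inhibition of growth and lower numbers for stronger inhibition of growth), compound 2 holds the highest of the two numbers, although a 1.8-fold higher number from compound 1 to compound 2 (0.26 log units; within the scatter) lies within the scatter, so the two compounds cannot be ordered. Compound 3 `COc1cccc(OC)c1OCCNCCOc1ccccc1OCc1ccc([N+](=O)[O-])cc1` differs from compound 2 by 4-nitrophenyl in place of 3-methylphenyl on a saturated chain carbon bound to an oxygen on an aromatic ring. Among the measured compounds shown here, the only measured step that bears on this place, a 1.8-fold higher number from compound 1 to compound 2 (0.26 log units; within the scatter), exchanged one aryl group for another on the same chain carbon and stayed within the scatter; no measured step involves a nitro group. Compound 3 is therefore expected to show no step beyond the scatter in this assay, a 1.3-fold lower number from compound 2 to compound 3 (0.11 log units; within the scatter), with an estimate of 25000 nM and a range from 8000 nM to 80000 nM.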

Compound 3, concentration for total growth inhibition: 43600 nM
Beside the measured number, compound 3's estimate is 1.7-fold (0.24 log units) below it; the measured number falls inside the stated range.
By their numbers in this assay, from the lowest: compounds 1, 2 and 3 (each within the scatter of the next, the first and the last beyond it).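

In this assay, among the compounds shown here, 4-nitrophenyl in place of 2-chlorophenyl gives a 2.4-fold higher number from compound 1 to compound 3 (0.39 log units; beyond the scatter) and so is the first change at this position to pass beyond the scatter, though only modestly, while 4-nitrophenyl in place of 3-methylphenyl gives a 1.3-fold higher number from compound 2 to compound 3 (0.13 log units; within the scatter) and stays within it. Compound 1 and compound 3 can thus be ordered, but compound 2 cannot be set apart from either. Nothing available accounts for this step. The compounds shown leave open whether an amine or a carboxylic acid on this aromatic ring would move the number further, and whether the group or its place on the ring matters more.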